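Cyclic Ether Replaces Open Chain on the Aryl Oxygen

The compounds below may be only part of what the source reports. "The series", "measured", "known", "first", "only" and "open" are said of these compounds alone.

Among the compounds with values here, compound 2 `CCOCCOc1cc(C)c(-c2cccc(COc3ccc(CCC(=O)O)c(F)c3)c2)c(C)c1` holds the lower of the two numbers measured so far in an assay on CHO cells for displacement of a labelled ligand from Free fatty acid receptor 1 (Rattus norvegicus), read by scintillation counting, with a stated time of 90 min, in the presence of a further agent that is not named here (a lower number here means a stronger inhibitor, a higher number a weaker inhibitor), where compound 2 gives 4.5 nM. Within the data shown here, compound 1 `COc1ccc(COc2ccc(CCC(=O)O)cc2)cc1-c1c(C)cccc1C` is the only other measured compound; in this assay compound 1 gives 87 nM, a higher number that lies beyond the scatter. Compound 3 `Cc1cc(OC2CCOCC2)cc(C)c1-c1cccc(COc2ccc(CCC(=O)O)c(F)c2)c1` differs from compound 2 by one change: oxan-4-yl in place of 2-ethoxyethyl on an oxygen on an aromatic ring. Among the measured compounds shown here, no measured pair shows this exchange, so only an expectation can be offered: no step beyond the scatter is expected, with a 1.1-fold higher number from compound 2 to compound 3 (0.05 log units; within the scatter) as the anticipated step. Compound 3 is therefore estimated at 5 nM in this assay, within 1.5 nM to 15 nM.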

Compound 3, inhibition constant: 6.7 nM
Beside the measured number, compound 3's estimate is 1.3-fold (0.13 log units) below it; measured number inside the range.
By their numbers in this assay, from the lowest: compounds 2 and 3 (each within the scatter of the next); then compound 1.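

On an oxygen on an aromatic ring, the exchange of 2-ethoxyethyl for oxan-4-yl brings a 1.5-fold higher number from compound 2 to compound 3 (0.17 log units; within the scatter) in this assay and so leaves the two compounds indistinguishable. This first single-place comparison shows that the open chain and a six-membered non-aromatic ring with one hetero atom can stand at this position without a step beyond the scatter. Nothing available explains this match.

The compounds shown leave open whether an amine on the ring, such as piperidin-4-yl, or a longer ether chain on the same oxygen would keep the number in this range.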